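This account rests on a few compounds, and the source may have more. Where it says the series, first, only, none or still open, it means among the compounds named here.

Among the compounds with values here, in a functional assay on MCF7 cells (Homo sapiens) for antiproliferative activity, read by MTT assay, with a stated time of 72 h (a higher number here means a weaker inhibitor, a lower number a stronger inhibitor), compound 1 (`COc1ccc(/C=C2\S/C(=N\c3ccc(Cl)cc3)N(C)C2=O)cc1`) gives 39300 nM, the only true number in this small series. Compound 2 (`COc1ccc(/C=C2\S/C(=N\c3ccc(C)c(Cl)c3)N(C)C2=O)cc1`) reads > 100000 nM, which is a limit of the assay and not a number.

The next structure is compound 3 (`COc1ccc(/C=C2\S/C(=N\c3ccc(C(C)(C)C)cc3)N(C)C2=O)cc1`), with tert-butyl in place of chloro on an aromatic carbon, para to a large group: tert-butyl in place of chloro on an aromatic carbon. Within the data shown here, one measured step bears on this change, and only indirectly: an at least 2.5-fold higher number from compound 1 to compound 2 (0.40 log units; beyond the scatter), with 3-chloro-4-methylphenyl in place of 4-chlorophenyl on the double-bonded nitrogen. That step alters the same aromatic group as the change in compound 3 and goes toward a weaker inhibitor, so a modest move in the same direction is expected in this assay. A single step bounded by a limit is thin support, and a reading that is itself only a limit would be no surprise.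

The expected change is a 2.2-fold higher number from compound 1 to compound 3 (0.34 log units; beyond the scatter). For compound 3 the estimated value is 85000 nM, with an expected range of 35000 nM to 200000 nM.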

Compound 3, half-maximal inhibitory concentration: > 100000 nM
Compound 3: no number, only a limit (the forecaster's own chance of this, stated with the estimate: 45%); at least 1.1-fold (0.07 log units) between middle value and limit.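

Tert-butyl in place of chloro on an aromatic carbon, para to a large group, gives an at least 2.5-fold higher number from compound 1 to compound 3 (0.40 log units; beyond the scatter) in this assay; unlike the earlier step, which brought in a 3-chloro-4-methylphenyl group, this one replaces a single group at one place on the aromatic ring, so a move toward a weaker inhibitor is now tied to that place alone. Compound 3 reads > 100000 nM, which is a limit of the assay and not a number. The printed step is therefore only a lower bound on the change, and the true size of the tert-butyl effect stays unknown, because the series has reached the same ceiling twice: the limit of > 100000 nM in this assay, at which 2 of the 3 values shown sit.

With compound 1 the only compound holding a true number, compounds 2 and 3 cannot be placed in any order, and nothing shown identifies a replacement for chloro at this place that gives a lower number. Open as well is how a fluoro, methoxy or amine group, or a carboxylic acid, would read at this same place on the shared core, and whether any of them would stay inside the measurable range of this assay.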